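The source may hold more compounds than are shown below. What is called first, only, known or untested is meant among the compounds shown, and "the series" means these compounds.

Of the compounds shown here, three have so far been measured in an ADME assay on microsomes from liver (Homo sapiens) for metabolic stability, read by HPLC, using NADPH, with a stated time of 60 min, tested at 1 uM, in the presence of a further agent that is not named here; on this read-out lower numbers stand for slow clearance and higher numbers for fast clearance. Compound 1 `O=C(NNS(=O)(=O)c1ccccc1F)c1cc(F)cc(-c2ccccn2)c1` gives 31 uL/min. Compound 2 `Cc1cc(-c2ncccn2)cc(C(=O)NNS(=O)(=O)c2ccccc2)c1F` gives 11 uL/min. Compound 3 `Cc1cc(C(=O)NNS(=O)(=O)c2ccccc2F)cc(-n2cc(F)cn2)c1` gives 143 uL/min. Compound 2 thus stands lowest of the three, with compound 1 nearest to it and compound 3 furthest away, and both of those gaps lie beyond the usual scatter of repeated measurements. No two of these three compounds differ in only one place, so no single structural step can be read from them.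

Compound 4 `C=CCOc1cc(C)c(F)c(C(=O)NNS(=O)(=O)c2ccccc2)c1` has not yet been measured in this assay. It differs from compound 2 in one place: allyloxy in place of pyrimidin-2-yl on an aromatic carbon. Going by the values given here, with no measured step of this kind to lean on, the expectation rests on compound 2 alone, whose value of 11 uL/min is the starting point. The step is expected to run upward, beyond the scatter: a 4.5-fold higher number from compound 2 to compound 4 (0.66 log units; beyond the scatter). Compound 4 is accordingly expected to give about 50 uL/min, within a range from 15 uL/min to 160 uL/min.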

Compound 4, intrinsic clearance in a liver preparation (reported as CLH), per the amount of preparation that the assay uses: 73 uL/min
The estimate for compound 4 lay 1.5-fold (0.16 log units) below the measured number; measured number inside the range.
By their numbers in this assay, from the lowest: compound 2; then compound 1; then compounds 4 and 3 (each within the scatter of the next).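

In this assay, going by these compounds alone, the swap of pyrimidin-2-yl for allyloxy gives a 6.6-fold higher number from compound 2 to compound 4 (0.82 log units; beyond the scatter) on an aromatic carbon para to the fluoro group and meta to the methyl group, the first change in this set that can be read on its own. This shows that clearance in this series responds to what sits at this position, as the step lies beyond the scatter when a six-membered aromatic ring gives way to a chain without a ring that carries a double bond. Nothing measured here explains why the number rises.

Going by these compounds, with a single pair, it remains open whether the rise comes from losing pyrimidin-2-yl or from gaining allyloxy. Methoxy or a saturated propoxy chain at the same place would help to separate the chain's length and its double bond.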